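The source may report more compounds than this note shows. Statements on the series, on what has been measured and on what is new or still open speak of the compounds shown alone.

In a functional assay on RAW264.7 cells (Mus musculus) for inhibition, read by fluorescence, with stated times of 1 h, 24 h and 30 min (on this read-out lower numbers stand for stronger inhibition and higher numbers for weaker inhibition), compound 1 (`O=C(/C=C/c1cccc(F)c1)c1ccc(O)cc1`) gives 9150 nM and compound 2 (`O=C(/C=C/c1cccc(C(F)(F)F)c1)c1ccc(O)cc1`) gives 1440 nM. Compound 3 (`O=C(/C=C/c1cccc(OC(F)(F)F)c1)c1ccccc1O`) has no number to stand on, as its entry reads "not determined" (no result reported). It therefore offers no starting value for the step to compound 4 (`O=C(/C=C/c1cccc(OC(F)(F)F)c1)c1ccc(O)cc1`).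

The structural change is a swap of one group for its isomer: 4-hydroxyphenyl in place of 2-hydroxyphenyl on a carbonyl carbon. Put simply, 4-hydroxyphenyl takes the place of 2-hydroxyphenyl on a carbonyl carbon, while the trifluoromethoxy group stays in both compounds. Among the measured compounds shown here, no measured pair shows this swap, so neither the size nor the direction of the step from compound 3 can be predicted.

For the measured compounds named here, only one measured step offers indirect help: a 6.4-fold lower number from compound 1 to compound 2 (0.80 log units; beyond the scatter). That step replaces fluoro with trifluoromethyl, and it shows that the group on the far side of the shared core can move the number beyond the scatter. Compound 4 keeps the 4-hydroxyphenyl of compound 1 and compound 2 but carries trifluoromethoxy, a group not yet measured on this background. The value of compound 4 is therefore expected to fall near the span set by compound 1 and compound 2, closer to that of compound 2 at 1440 nM, the other compound with a fluorinated carbon group.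

For compound 4 the expected value is 2000 nM, with an estimated range from 600 nM to 7000 nM.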

Compound 4, half-maximal inhibitory concentration: > 10000 nM
Compound 4 ended at the assay's limit (the forecaster's own chance of this, stated with the estimate: 5%); middle value at least 5.0-fold (0.69 log units) from the limit.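

Compound 4 does not reach a measurable number in this assay; its result is a limit: the limit of > 10000 nM in this assay, at which 1 of the 4 values shown sits. This gives the first view of trifluoromethoxy on the aromatic carbon that carries fluoro in compound 1 and trifluoromethyl in compound 2, with 4-hydroxyphenyl kept on the carbonyl carbon in all three. Trifluoromethoxy in place of trifluoromethyl gives an at least 6.9-fold higher number from compound 2 to compound 4 (0.84 log units; beyond the scatter), so these two fluorinated groups are not interchangeable at this carbon, while trifluoromethoxy in place of fluoro gives an at least 1.0-fold higher number from compound 1 to compound 4 (0.03 log units; that floor lies within the scatter), which sets no order between those two compounds.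

Compound 3 has no result, so the step to compound 4 cannot be read, and the swap of 2-hydroxyphenyl for 4-hydroxyphenyl on the carbonyl carbon remains an open question. Also open, on these data alone, is whether a methoxy group, a nitrile or an amine on the same aromatic carbon would give a number in the range of compound 2 or would instead end at the limit, as trifluoromethoxy does in compound 4.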